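The compounds below may be only part of what the source reports. "The series", "measured", "known", "first", "only" and "open" are said of these compounds alone.

In a functional assay on M21 cells (Homo sapiens) for antiproliferative activity, read by sulforhodamine B assay, with a stated time of 48 h (a lower number here means a stronger inhibitor, a higher number a weaker inhibitor), two compounds of the series have been measured so far. Compound 1 `Cc1cccc(OS(=O)(=O)c2ccc(N3CCN(C)C3=O)cc2)c1` gives 2300 nM. Compound 2 `CCCCN1CCN(c2ccc(S(=O)(=O)Oc3ccccc3)cc2)C1=O` gives > 100000 nM, which is a limit of the assay and not a number. Any step starting from compound 2 therefore has no exact size.

Compound 3 `CCCCN1CCN(c2ccc(S(=O)(=O)Oc3cccc(Br)c3)cc2)C1=O` keeps the butyl chain of compound 2 and differs from it in one place: bromo in place of hydrogen on an aromatic carbon. This is bromo in place of hydrogen on an aromatic carbon, meta to a large group, turning phenoxy to 3-bromophenoxy.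

Going by the values given here, no measured pair isolates this change, so the expectation is loose. Among the compounds with values here, the only guide is compound 1 at 2300 nM, which also bears a substituent on its phenoxy ring but carries a different chain as well. A large move towards stronger inhibition is expected in this assay, although compound 3 could also remain at the limit. The estimated change is an at least 12-fold lower number from compound 2 to compound 3 (1.09 log units; beyond the scatter). Compound 3 is expected to give about 8000 nM, within an estimated range from 1500 nM to 50000 nM.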

Compound 3, half-maximal inhibitory concentration: 35000 nM
For compound 3 the middle estimate is 4.4-fold (0.64 log units) below the measured one; low and high end bracket the measured number.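

Bromo in place of hydrogen on an aromatic carbon, turning phenoxy to 3-bromophenoxy, gives in this assay an at least 2.8-fold lower number from compound 2 to compound 3 (0.45 log units; beyond the scatter), the first step in the series that isolates a change in one place. The phenoxy ring of the butyl compounds therefore responds to substitution at this carbon, and a single bromine atom is enough for compound 3 to give a measured value of 35000 nM. Compound 2 has only a limit and not a number, so the step fixes a direction and a minimum size, with its true size unknown: the limit of > 100000 nM in this assay, at which 1 of the 3 values shown sits.

The compounds shown leave open whether a chloro, methyl or methoxy group at the same carbon would give a similar step, or whether bromine itself is needed. They also leave open whether the bromo step would carry over to a core with a methyl or a hexyl chain in place of butyl, as compound 1 differs from compound 3 in more than one place and cannot settle that.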